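From a cyclohexyl to a chloro-fluorophenyl group

A few compounds are considered here, and "the series" means these few. Any claim that something is new, unique, unknown or untested is made for them only; others in the source may bear on it.

Compound 1 `C[C@]1(CN2CCc3nc(C4CCCCC4)ccc3C2)Cn2cc([N+](=O)[O-])nc2O1` carries a cyclohexyl group on the shared core. In an ADME assay on Vero cells (Chlorocebus sabaeus) for cytotoxicity, read by MTT assay, with a stated time of 72 h (on this read-out lower numbers stand for higher toxicity in this test and higher numbers for lower toxicity in this test), compound 1 gives "not determined" (no result reported), so no number places it. Compound 2 `C[C@]1(CN2CCc3nc(-c4cc(F)cc(F)c4)ccc3C2)Cn2cc([N+](=O)[O-])nc2O1` carries a 3,5-difluorophenyl group instead. In this assay compound 2 gives > 32 ug/mL, a limit of the assay rather than a number. Compound 3 `C[C@]1(CN2CCc3nc(-c4cc(F)ccc4F)ccc3C2)Cn2cc([N+](=O)[O-])nc2O1` carries a 2,5-difluorophenyl group. In this assay compound 3 gives > 32 ug/mL, again a limit. The step that the two limits leave unreadable from compound 2 to compound 3 cannot be read, since both of its ends sit at the limit. The measured values cluster at the limit of > 32 ug/mL in this assay, at which 2 of the 3 values shown sit.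

Compound 4 `C[C@]1(CN2CCc3nc(-c4cc(Cl)ccc4F)ccc3C2)Cn2cc([N+](=O)[O-])nc2O1` differs from compound 1 in one place: 5-chloro-2-fluorophenyl in place of cyclohexyl on an aromatic carbon. Going by the values given here, no measured step bears directly on this change, and compound 1 itself has no number to start from. Among the compounds with values here, the only guidance is that the two halogenated phenyl analogues, compound 2 and compound 3, both sit at the limit in this assay, so a further halogenated phenyl ring on the shared core is expected to behave the same way, with no readable step. Compound 4 is therefore estimated at 40 ug/mL in this assay, within 16 ug/mL to 100 ug/mL, and the result is expected most likely to be reported only as a limit.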

Compound 4, half-maximal cytotoxic concentration: > 32 ug/mL
Compound 4 was reported as a limit; the forecaster's own chance of this, stated with the estimate: 75%; the middle value lies beyond the limit too.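

Compound 4 adds no readable step, since its steps from compound 2 and from compound 3 cannot be read, all three compounds ending at the same limit in this assay: the limit of > 32 ug/mL in this assay, at which 3 of the 4 values shown sit.

The compounds shown leave open whether compound 2, compound 3 and compound 4 differ from one another at all, and where compound 1, with its cyclohexyl group, stands among them.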